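From diethylamino to a piperidin-1-yl ring

The source may report more compounds than this note shows. Statements on the series, on what has been measured and on what is new or still open speak of the compounds shown alone.

In a functional assay on DU-145 cells (Homo sapiens) for cytotoxicity, read by MTT assay, with a stated time of 72 h (a lower number here means a stronger inhibitor, a higher number a weaker inhibitor), compound 1 `CNc1cc2nc(-c3ccccc3)nn(-c3ccccc3)c-2cc1=O` gives 980 nM, and compound 2 `CCN(CC)c1cc2nc(-c3ccccc3)nn(-c3ccccc3)c-2cc1=O` gives 3110 nM. Within the data shown here, that makes compound 2 the higher of the two numbers so far, and so the weaker inhibitor. Among the measured compounds shown here, its only neighbour on the scale is compound 1.

The next compound, compound 3 `O=c1cc2n(-c3ccccc3)nc(-c3ccccc3)nc-2cc1N1CCCCC1`, has not yet been measured. It carries piperidin-1-yl in place of diethylamino on an aromatic carbon. The rest of the structure stays the same.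

For the measured compounds named here, only one measured step bears on this change: a 3.2-fold higher number from compound 1 to compound 2 (0.50 log units; beyond the scatter). It is a modest step beyond the scatter, and it swaps one open amino group for another at the same place. Neither measured compound has a ring there, so the data give only weak guidance and do not settle the direction. A step smaller than that one seems the likeliest outcome in this assay, with a slight lean towards a lower number.

The estimated step is a 1.2-fold lower number from compound 2 to compound 3 (0.09 log units; within the scatter), probably within the scatter. Compound 3 is expected at 2500 nM, with an estimated range of 900 nM to 6500 nM.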

Compound 3, half-maximal inhibitory concentration: 610 nM
The estimate for compound 3 lay 4.1-fold (0.61 log units) above the measured number; measured number outside the range, below it.
By their numbers in this assay, from the lowest: compounds 3 and 1 (each within the scatter of the next); then compound 2.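

Closing the two ethyl chains of diethylamino into a piperidin-1-yl ring, which adds one carbon and keeps nitrogen as the attached atom, matters at this position: in this assay the change gives a 5.1-fold lower number from compound 2 to compound 3 (0.71 log units; beyond the scatter) and so reverses the rise seen with the open chains. Heavy-atom count alone therefore does not track the number across these groups, as piperidin-1-yl is the largest of the three, yet the change from methylamino gives a 1.6-fold lower number from compound 1 to compound 3 (0.21 log units; within the scatter) and leaves compound 3 and compound 1 within the scatter of each other. No measurement here explains why the ring and the open chains differ.

The compounds shown leave open whether this result depends on the ring having six members, which a five-membered pyrrolidin-1-yl ring or a seven-membered azepan-1-yl ring would test. They also leave open whether the ring tolerates a second hetero atom, as in morpholin-4-yl with its ring oxygen or a piperazine ring with its second nitrogen.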